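Fluorine shifted on compound 3, cytotoxicity expected unchanged

The compounds below may be only part of what the source reports. "The series", "measured", "known", "first", "only" and "open" are said of these compounds alone.

Three close analogues share one core. Compound 1 `CC(C)Cc1nn(-c2nccs2)cc1C(=O)NCc1cccc(F)c1` in a toxicity assay on HepG2 2.2.15 cells (Homo sapiens) for cytotoxicity, read by CCK-8 assay, with a stated time of 8 days (on this read-out lower numbers stand for higher toxicity in this test and higher numbers for lower toxicity in this test), reaches only a limit, > 100000 nM, not a measured number. Compound 2 `CC(C)Cc1nn(-c2nccs2)cc1C(=O)NCc1ccc(C(F)(F)F)cc1` likewise gives only a limit in this assay, > 100000 nM. Compound 3 `CC(C)Cc1nn(-c2nccs2)cc1C(=O)NCc1ccccc1F` also stands at a limit in this assay, > 100000 nM, so its place among the other two cannot be read. The step that the two limits leave unreadable from compound 1 to compound 3 stays unreadable because the limit of > 100000 nM in this assay, at which 3 of the 3 values shown sit, holds every value shown.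

Compound 4 `CC(C)Cc1nn(-c2nccs2)cc1C(=O)NCc1ccc(F)cc1` differs from compound 3 by 4-fluorophenyl in place of 2-fluorophenyl on a saturated chain carbon bound to an amide-type nitrogen. Within the data shown here, no measured step gives a readable size that bears on this change. The step that the limit leaves unreadable from compound 3 to compound 4 is therefore expected to stay within the scatter. For compound 4 the expected value in this assay is 150000 nM, with a range from 70000 nM to 400000 nM, most likely again as a limit.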

Compound 4, half-maximal cytotoxic concentration: > 100000 nM
Compound 4: only a limit was reported (the forecaster's own chance of this, stated with the estimate: 90%); the middle value is on the limit's open side.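

No step from compound 1, compound 2 or compound 3 to compound 4 can be read in this assay, because every value is a limit: the limit of > 100000 nM in this assay, at which 4 of the 4 values shown sit.

The compounds shown leave open whether moving the fluorine or replacing trifluoromethyl with fluoro changes cytotoxicity at all.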